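The source may report more compounds than this note shows. Statements on the series, on what has been measured and on what is new or still open speak of the compounds shown alone.

Compound 1 `CN(C)c1ccc2cc(-c3ccccc3)c(N)nc2c1` is the starting point of this account. In an ADME assay on microsomes from liver (Mus musculus) for metabolic stability, read by HPLC, with a stated time of 4 h (a lower number here means that the compound disappears faster, a higher number that the compound lasts longer), compound 1 gives < 0.1 h, which is a limit of the assay and not a number. Its position is therefore known only as the limit of < 0.1 h in this assay, at which 1 of the 2 values shown sits. Within the data shown here, the one other compound measured on the same core, compound 2 `CN(C)c1ccc2cc(-c3cccc(Cl)c3Cl)c(N)nc2c1`, gives 0.15 h, so a numerical reading exists for only one of the pair.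

The next compound, compound 3 `CN(C)c1ccc2cc(-c3ccccn3)c(N)nc2c1`, keeps the core of compound 1 and carries pyridin-2-yl in place of phenyl on an aromatic carbon. The swap sits ortho to an amino group, and the rest of the structure is unchanged.

Among the measured compounds shown here, no measured step between compounds differing in one place is available to set the scale of this change. For the measured compounds named here, the expectation therefore rests on compound 2 at 0.15 h as the only numerical guide, and only a small shift in this assay is anticipated. The expected change is an at least 1.2-fold higher number from compound 1 to compound 3 (0.07 log units; that floor lies within the scatter), and a reading at the limit remains quite possible. For compound 3 the estimated half-life is 0.12 h, with an expected range from 0.06 h to 0.35 h.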

Compound 3, half-life: < 0.1 h
Compound 3: no number, only a limit; the forecaster's own chance of this, stated with the estimate: 40%; middle value at least 1.2-fold (0.07 log units) from the limit.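

In this assay compound 3 gives < 0.1 h as a limit and not a number. Compound 1 also stands at a limit, so no step can be read between compound 1 and compound 3. The shared reading is this: the limit of < 0.1 h in this assay, at which 2 of the 3 values shown sit. As far as these compounds go, whether pyridin-2-yl in place of phenyl on an aromatic carbon changes the half-life at all remains open.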